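Swapping the amide for a pyrimidinyl amine in a cytotoxicity series

This account rests on a few compounds, and the source may have more. Where it says the series, first, only, none or still open, it means among the compounds named here.

Measured compounds:
- compound 1 `CC(=O)c1cc(C(=O)N[C@@H](C)Cn2ccc(-c3cc(F)c(C#N)c(Cl)c3)n2)n[nH]1` — 27700 nM
- compound 2 `C[C@@H](Cn1ccc(-c2ccc(C#N)c(Cl)c2)n1)NC(=O)c1ccccc1F` — "not determined" (no result reported)
- compound 3 `CC(=O)c1cccc(NC(=O)C(C)Cn2ccc(-c3ccc(C#N)c(Cl)c3)n2)c1` — "not determined" (no result reported)

Among the compounds with values here, in an ADME assay on L02 cells (Homo sapiens) for cytotoxicity, read by CCK-8 assay, with a stated time of 6 days (a lower number here means a stronger inhibitor, a higher number a weaker inhibitor), compound 1 gives 27700 nM, the only number in the set. Compound 2 stands without a value: in this assay compound 2 gives "not determined" (no result reported), and compound 3 likewise gives "not determined" (no result reported), so compound 2 cannot be placed against anything measured. Compound 4 `C[C@@H](Cn1ccc(-c2ccc(C#N)c(Cl)c2)n1)Nc1cncnc1` is the next entry. pyrimidin-5-yl in place of (2-fluorophenyl)carbonyl on an amine nitrogen The carbonyl and the six-membered aromatic ring of carbon only leave; a six-membered aromatic ring with two hetero atoms enters. Within the data shown here, with no step between measured compounds to lean on, no direction can be read for this change, and any step beyond the scatter would be a guess. Compound 4 is expected to fall near 25000 nM, within 8000 nM to 70000 nM, given that compound 1 gives 27700 nM.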

Compound 4, half-maximal inhibitory concentration: > 30000 nM
Compound 4 was reported as a limit (the forecaster's own chance of this, stated with the estimate: 40%); middle value at least 1.2-fold (0.07 log units) from the limit.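

In this assay compound 4 gives > 30000 nM, a limit and not a number. Compound 2 has no single number, so no step can be read between compound 2 and compound 4. On these data alone, whether pyrimidin-5-yl in place of (2-fluorophenyl)carbonyl changes cytotoxicity stays open.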